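Dihydroxy for dimethoxy on two related cores

The source may report more compounds than this note shows. Statements on the series, on what has been measured and on what is new or still open speak of the compounds shown alone.

Measured in a functional assay on RS4-11 cells (Homo sapiens) for inhibition, read by CCK-8 assay, with a stated time of 48 h; a higher number here means a weaker inhibitor, a lower number a stronger inhibitor:
compound 1 `COc1ccc(Oc2ccc(C(C)C)cc2-c2ccsc2S(=O)(=O)NCCNC(=S)Nc2ccc([N+](=O)[O-])cc2)cc1OC` gives 5800 nM
compound 2 `CC(C)c1ccc(Oc2ccc(O)c(O)c2)c(-c2ccsc2S(=O)(=O)NCCNC(=S)Nc2ccc([N+](=O)[O-])cc2)c1` gives 5100 nM
compound 3 `COc1ccc(Oc2ccccc2-c2ccsc2S(=O)(=O)N2CCN(C(=O)Nc3ccc([N+](=O)[O-])cc3)CC2)cc1OC` gives > 50000 nM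

Compound 3 stands at a limit of this assay, and that limit is the limit of > 50000 nM in this assay, at which 1 of the 3 values shown sits; no number is known for it.

Between compound 1 and compound 2 the change is 3,4-dihydroxyphenyl in place of 3,4-dimethoxyphenyl on an oxygen on an aromatic ring. The step of a 1.1-fold lower number from compound 1 to compound 2 (0.06 log units; within the scatter) is within the scatter, so the two values show no change that can be read.

Compound 4 `O=C(Nc1ccc([N+](=O)[O-])cc1)N1CCN(S(=O)(=O)c2sccc2-c2ccccc2Oc2ccc(O)c(O)c2)CC1` has not yet been measured in this assay. It is made from compound 3 by 3,4-dihydroxyphenyl in place of 3,4-dimethoxyphenyl on an oxygen on an aromatic ring, the same change as between compound 1 and compound 2, at the same place on the shared oxygen on the aromatic ring. How the core of compound 3 differs from the core of compound 1 is not broken down here.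

On the earlier step, the expected step that the limit leaves unreadable from compound 3 to compound 4 is small, since the pair of compound 1 and compound 2 gave a 1.1-fold lower number from compound 1 to compound 2 (0.06 log units; within the scatter). Because compound 3 sits at the limit of > 50000 nM in this assay, at which 1 of the 3 values shown sits, compound 4 is expected to remain close to that limit, and most likely the assay will again report only a limit. For compound 4 in this assay the estimate is 60000 nM, with a range from 25000 nM to 150000 nM.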

Compound 4, half-maximal inhibitory concentration: 14300 nM
Beside the measured number, compound 4's estimate is 4.2-fold (0.62 log units) above it; the measured number lies below the stated range.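

In this assay, 3,4-dihydroxyphenyl in place of 3,4-dimethoxyphenyl gives an at least 3.4-fold lower number from compound 3 to compound 4 (0.54 log units; beyond the scatter), so the outcome of this change on the core of compound 1 does not carry over unchanged to the core of compound 3: the same change on two cores in this assay, a 1.1-fold lower number (0.06 log units; within the scatter) from compound 1 to compound 2 and an at least 3.4-fold lower number (0.54 log units; beyond the scatter) from compound 3 to compound 4, at least 3.0-fold (0.48 log units) apart, beyond the scatter of two such steps Compound 3 gives > 50000 nM, which is a limit and not a number: the limit of > 50000 nM in this assay, at which 1 of the 4 values shown sits. The step on this second core is therefore known only as a minimum, and the two pairs show that the size of the step depends on the core, but not how large the step truly is, which feature of the core sets it, or whether the same holds on any third core.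

Still open is which of the differences between the core of compound 1 and the core of compound 3 matters, as these differences are not separated in the pairs shown. From the compounds shown here alone, it is also open whether both hydroxyl groups are needed for the step on the core of compound 3, or whether an amine or a carboxylic acid on the same phenyl ring would give a similar step in this assay.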